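Adding a Methyl to a Branched Ether Chain

This account rests on a few compounds, and the source may have more. Where it says the series, first, only, none or still open, it means among the compounds named here.

Compound 1 `CCCOc1nc(C(C)(C)C)ccc1CNC(=O)C(C)c1ccc(NS(C)(=O)=O)c(F)c1` and compound 2 `CCCCOc1nc(C(C)(C)C)ccc1CNC(=O)C(C)c1ccc(NS(C)(=O)=O)c(F)c1` share one core; compound 3 `CC(C)COc1cc(C(C)(C)C)ccc1CNC(=O)C(C)c1ccc(NS(C)(=O)=O)c(F)c1` and compound 4 `CC(C(=O)NCc1ccc(C(C)(C)C)cc1OCC(C)(C)C)c1ccc(NS(C)(=O)=O)c(F)c1` share another, and the difference between the two cores is not broken down here. In an assay on cells for antagonist activity at transient receptor potential cation channel subfamily V member 1 (Homo sapiens), read by FLIPR and calcium flux, with a stated time of 6 min (a higher number here means a weaker inhibitor, a lower number a stronger inhibitor), compound 1 gives 1.7 nM, compound 2 gives 0.9 nM, and compound 3 gives 2.1 nM. Compound 2 differs from compound 1 by methyl in place of hydrogen on a saturated chain carbon, three bonds along the chain from an oxygen on an aromatic ring, and this brought a 1.9-fold lower number from compound 1 to compound 2 (0.28 log units; within the scatter). Compound 4 differs from compound 3 by methyl in place of hydrogen on a saturated chain carbon bound to three saturated chain carbons. The new methyl again enters on a saturated chain carbon, but here that carbon is bound to three saturated chain carbons, whereas in the earlier pair it stood three bonds along the chain from an oxygen on an aromatic ring, so this is the same kind of change, not the same one. A step of about the same size is expected for compound 4, a 1.5-fold lower number from compound 3 to compound 4 (0.18 log units; within the scatter), with wide allowance since the core and the place differ. This expectation rests on the step of a 1.9-fold lower number from compound 1 to compound 2 (0.28 log units; within the scatter). Compound 4 is therefore estimated at 1.4 nM in this assay, with a likely range from 0.5 nM to 4 nM.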

Compound 4, inhibition constant: 3.8 nM
For compound 4 the middle estimate is 2.7-fold (0.43 log units) below the measured one, and the stated range covers the measured number.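

In this assay the added methyl gave a 1.8-fold higher number from compound 3 to compound 4 (0.26 log units; within the scatter), so taken alone this step is no larger than the spread between repeated measurements. Set beside the earlier step, it points the opposite way, and the gap between the two is larger than that spread would readily give: the same change on two cores in this assay, a 1.9-fold lower number (0.28 log units; within the scatter) from compound 1 to compound 2 and a 1.8-fold higher number (0.26 log units; within the scatter) from compound 3 to compound 4, 3.4-fold (0.53 log units) apart, beyond the scatter of two such steps This shows that the effect of adding this methyl did not carry over unchanged from the core of compound 1 to the core of compound 3, but it does not show what lies behind the gap, as the two pairs differ both in the core and in the place of the methyl, and one pair on each core cannot separate the two.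

The compounds shown leave open how a neopentyloxy chain would read on the core of compound 1, which would put the same chain on both cores. They also leave open how a longer chain such as pentyloxy, or a ring-bearing chain such as cyclopropylmethoxy, would read on either core.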